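From Hydroxy to Acetoxy: One Small Change Tested

The source may report more compounds than this note shows. Statements on the series, on what has been measured and on what is new or still open speak of the compounds shown alone.

Of the compounds shown here, two have been measured so far in a functional assay on J82 cells (Homo sapiens) for cytotoxicity, read by colorimetric assay and MTT assay; on this read-out lower numbers stand for stronger inhibition and higher numbers for weaker inhibition. Compound 1 (`COc1cc(OC)c2cc(-c3ccccc3)c(O)nc2c1`) gives 10000 nM. Compound 2 (`COc1cc(OC)c2cc(-c3ccc(O)cc3)c(=O)n(C)c2c1`) gives 10000 nM, so it stands level with compound 1, and the two cannot be told apart on these numbers.

The next compound is compound 3 (`COc1cc(OC)c2cc(-c3ccc(OC(C)=O)cc3)c(=O)n(C)c2c1`), which differs from compound 2 in one place: acetyl in place of hydrogen on an oxygen on an aromatic ring. Put simply, a hydroxy group becomes an acetoxy group, with acetyl in place of hydrogen on an oxygen on an aromatic ring.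

For the measured compounds named here, no two measured compounds differ in just one place, so the data offer no direct guide to what this change will do in this assay. Going by the values given here, the only anchor is compound 2 at 10000 nM, which suggests a cautious expectation. The expected change is small, a 1.4-fold lower number from compound 2 to compound 3 (0.15 log units; within the scatter), leaning towards stronger inhibition but not expected to go beyond the usual scatter. For compound 3 the estimated value is 7000 nM, with an expected range from 2000 nM to 12000 nM.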

Compound 3, half-maximal inhibitory concentration: 10000 nM
Compound 3: the middle estimate sits 1.4-fold (0.15 log units) below what was measured; measured number inside the range.
By their numbers in this assay, from the lowest: compounds 1, 2 and 3 (each within the scatter of the next).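

Placing acetyl on the oxygen on an aromatic ring gives no change at the digits printed from compound 2 to compound 3 (within the scatter) in this assay, and this is the first step in the series that can be read directly, since the earlier pair differed in more than one place. It shows that on this oxygen, in the setting of compound 2, a hydroxy group can give way to an acetoxy group without the number moving beyond the usual scatter, so this one change neither gains nor loses anything this read-out can register. The measurements at hand offer nothing that explains why the number holds steady.

On these data alone, a single step says little about the position as a whole, so it remains open whether a different group on that oxygen, such as a longer carbon chain or a chain ending in an amine or a carboxylic acid, would shift the number beyond the scatter. As far as these compounds go, it is equally open whether the same swap of hydroxy for acetoxy would leave the number unmoved on a compound with a different group elsewhere on the shared core.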